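The source may report more compounds than this note shows. Statements on the series, on what has been measured and on what is new or still open speak of the compounds shown alone.

In a functional assay on PC-3 cells (Homo sapiens) for cytotoxicity, read by WST assay, with a stated time of 72 h (on this read-out higher numbers stand for weaker inhibition and lower numbers for stronger inhibition), two compounds have been measured so far. Compound 1 (`Cc1c(F)ccc2c1NC(=O)C2(c1ccc(O)cc1)C1CCCCCC1`) gives 30 nM, and compound 2 (`COc1ccc2c(c1C)NC(=O)C2(c1ccc(O)cc1)c1ccc(F)cc1`) gives 9 nM. Compound 2 therefore has the lower number of the two and is the stronger inhibitor, with a gap beyond the usual scatter of repeat measurements.

Compound 3 (`COc1ccc2c(c1C)NC(=O)C2(c1ccc(O)cc1)C1CCCCCC1`) keeps the core of compound 2 and changes one group: cycloheptyl in place of 4-fluorophenyl on a saturated ring carbon. In words, cycloheptyl stands in place of 4-fluorophenyl on a saturated ring carbon. The two measured compounds differ in more than one place, so the data hold no direct measurement of this swap. Among the measured compounds shown here, the only guide is indirect: compound 1 carries the same cycloheptyl on a different core and gives 30 nM, a higher number than compound 2. A small move toward weaker inhibition in this assay therefore seems the likeliest outcome, though it may not clear the scatter. The expected change is a 1.8-fold higher number from compound 2 to compound 3 (0.25 log units; within the scatter). Compound 3 is estimated at 16 nM, with an expected range of 5 nM to 50 nM.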

Compound 3, half-maximal inhibitory concentration: 12 nM
Beside the measured number, compound 3's estimate is 1.3-fold (0.12 log units) above it; low and high end bracket the measured number.
By their numbers in this assay, from the lowest: compounds 2 and 3 (each within the scatter of the next); then compound 1.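

In this assay the swap on the saturated ring carbon, two ring bonds from the ring nitrogen, stays within the scatter (a 1.3-fold higher number from compound 2 to compound 3 (0.12 log units; within the scatter)), so on this core the seven-membered non-aromatic carbon ring of cycloheptyl serves as well as the six-membered aromatic ring of 4-fluorophenyl, and for this pair an aromatic ring at this place is not required. Among the compounds shown here, compound 3 also gives the first one-place comparison on the aromatic carbon: with cycloheptyl held fixed, methoxy in place of fluoro brings a modest change that lies beyond the scatter (a 2.5-fold lower number from compound 1 to compound 3 (0.40 log units; beyond the scatter)), so the group on that carbon moves the number here, while the swap on the saturated ring carbon did not move it beyond the scatter. No measurement at hand explains either result.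

On these data alone, it remains open how a smaller ring such as cyclopentyl, an open chain such as n-butyl or a ring carrying an amine such as piperidinyl would fare on the saturated ring carbon. As far as these compounds go, it is also open whether methoxy in place of fluoro would give a similar step with 4-fluorophenyl on that carbon, and how ethoxy or chloro would compare on the aromatic carbon.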